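Swapping the aryl on the pyrazole nitrogen of compound 1

A few compounds are considered here, and "the series" means these few. Any claim that something is new, unique, unknown or untested is made for them only; others in the source may bear on it.

Within the data shown here, compound 1 `Cc1c(C(=O)Nc2ccc(C(F)(F)F)cc2)cnn1-c1ccc(F)c(Cl)c1` is the strongest inhibitor among the three compounds measured so far: in a functional assay with Homo sapiens as the target (a lower number here means a stronger inhibitor, a higher number a weaker inhibitor), compound 1 gives 1300 nM. Compound 2 `COc1cccc(NC(=O)c2cnn(-c3ccc(F)cc3)c2C)c1` gives 3700 nM and compound 3 `Cc1c(C(=O)Nc2ccccc2F)cnn1-c1ccc(F)cc1` gives 4000 nM, both higher numbers than compound 1 by margins that exceed the usual scatter. Among the measured compounds shown here, the one single-point step available, a 1.1-fold higher number from compound 2 to compound 3 (0.03 log units; within the scatter), concerns the aryl on the amide-type nitrogen and is within the scatter.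

Compound 4 `Cc1cccc(-n2ncc(C(=O)Nc3ccc(C(F)(F)F)cc3)c2C)c1` is obtained from compound 1 by the change (3-methylphenyl in place of 3-chloro-4-fluorophenyl on an aromatic nitrogen). For the measured compounds named here, no measured step touches the group on the aromatic nitrogen, so there is no direct precedent for this change; the step between compounds 2 and 3 does not bear on it. In the absence of such a precedent, a modest weakening is expected, with the number for compound 4 estimated at 2500 nM, between 1000 nM and 6500 nM. This corresponds to an expected step of a 1.9-fold higher number from compound 1 to compound 4 (0.28 log units; within the scatter).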

Compound 4, half-maximal inhibitory concentration: 2500 nM
Beside the measured number, compound 4's estimate shows no gap at the digits printed; low and high end bracket the measured number.
By their numbers in this assay, from the lowest: compounds 1, 4, 2 and 3 (each within the scatter of the next, the first and the last beyond it).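

Among these compounds, compound 4 gives the first reading at this position, on the aromatic nitrogen, with the rest of compound 1 held fixed: a 1.9-fold higher number from compound 1 to compound 4 (0.28 log units; within the scatter) in this assay. The two numbers cannot be told apart, so this assay does not separate 3-methylphenyl from 3-chloro-4-fluorophenyl here, even though the entering group carries neither the chlorine nor the fluorine of the leaving group. No evidence is available to explain this result.

The compounds shown leave open whether this nitrogen needs a six-membered aromatic ring of carbon at all, and how a cyclohexyl group or a pyridyl ring would read in its place. They also leave open whether the same swap would read alike with the 2-fluorophenyl or 3-methoxyphenyl amide in place of the 4-(trifluoromethyl)phenyl amide.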